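Replacing a fluorine with an amine-bearing side chain

The source may report more compounds than this note shows. Statements on the series, on what has been measured and on what is new or still open speak of the compounds shown alone.

Compound 1 has the structure `COc1cc(F)c(NC(=O)c2ccncc2)cc1Nc1nccc(-c2cn(C)c3ccccc23)n1`. Among the compounds with values here, in a functional assay on NCI-H1975 cells (Homo sapiens) for antiproliferative activity, read by MTT assay, with a stated time of 72 h (on this read-out higher numbers stand for weaker inhibition and lower numbers for stronger inhibition), compound 1 gives 4370 nM, the lowest of the two numbers measured so far. Within the data shown here, its only measured neighbour is compound 2, `COc1ccc(C(=O)Nc2cc(Nc3nccc(-c4cn(C)c5ccccc45)n3)c(OC)cc2F)nc1`, which in this assay gives 16800 nM; the step of a 3.8-fold higher number from compound 1 to compound 2 (0.58 log units; beyond the scatter) comes from a change on the carbonyl carbon, a different place from the one examined here.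

The new compound, compound 3, has the structure `COc1cc(N(C)CCN(C)C)c(NC(=O)c2ccncc2)cc1Nc1nccc(-c2cn(C)c3ccccc23)n1`. It differs from compound 1 in one place: (2-(dimethylamino)ethyl)(methyl)amino in place of fluoro on an aromatic carbon. Among the measured compounds shown here, no measured step touches this position, so the one known step gives no direct guide to its size or direction; it only shows that a single change can move the number beyond the scatter.

For the measured compounds named here, with no measured step bearing on it, the expectation for compound 3 rests on compound 1 alone and carries a wide range, and the estimated step of a 2.2-fold lower number from compound 1 to compound 3 (0.34 log units; beyond the scatter) is left open in direction. Compound 3 is expected to give about 2000 nM, within a range from 400 nM to 10000 nM.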

Compound 3, half-maximal inhibitory concentration: 6860 nM
The estimate for compound 3 lay 3.4-fold (0.54 log units) below the measured number; measured number inside the range.
By their numbers in this assay, from the lowest: compounds 1 and 3 (each within the scatter of the next); then compound 2.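

In this assay, within the data shown here, the swap of fluoro for (2-(dimethylamino)ethyl)(methyl)amino is the first measured change at this aromatic carbon, and its step (a 1.6-fold higher number from compound 1 to compound 3 (0.20 log units; within the scatter)) shows no change that can be told apart from the scatter, even though 1 heavy atom leaves and 7 heavy atoms enter. Among these compounds, the only earlier step (a 3.8-fold higher number from compound 1 to compound 2 (0.58 log units; beyond the scatter)) lies at the carbonyl carbon and goes beyond the scatter, so the series has now been probed in two places, and only that change has moved the number measurably. Nothing measured here explains why the larger chain leaves the number within the scatter.

One chain at this position cannot show whether its two nitrogens or its length have any bearing on the number; a lone dimethylamino group, a longer chain ending in the same amine, or a ring amine such as 4-methylpiperazin-1-yl would each test this. On these data alone, it also remains open whether the same chain would give a similar result on compound 2, which carries 5-methoxypyridin-2-yl on the carbonyl carbon.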